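Adding a second trifluoromethyl to the urea terminus

This account rests on a few compounds, and the source may have more. Where it says the series, first, only, none or still open, it means among the compounds named here.

Measured compounds:
Compound 1 `O=C(Nc1cccc(-n2cc(-c3ccncc3)c(-c3ccc(Cl)c(O)c3)n2)c1)Nc1cc(C(F)(F)F)cc(C(F)(F)F)c1`: 1090 nM
Compound 2 `COc1cc(-c2nn(-c3cccc(NC(=O)Nc4cccc(C(F)(F)F)c4)c3)cc2-c2ccncc2)ccc1Cl`: 1250 nM
Compound 3 `COc1cc(-c2nn(-c3cccc(NC(=O)c4ccccc4)c3)cc2-c2ccncc2)ccc1Cl`: 1330 nM

In a functional assay on BT-549 cells (Homo sapiens) for inhibition, read by sulforhodamine B assay, with a stated time of 48 h (a lower number here means a stronger inhibitor of growth, a higher number a weaker inhibitor of growth), compound 2 gives 1250 nM, a number that lies within the scatter of both compound 1 and compound 3, so the three cannot be told apart. For the measured compounds named here, the one step available, from the urea to a benzamide, was a 1.1-fold higher number from compound 2 to compound 3 (0.03 log units; within the scatter) and so showed no change beyond the scatter. Compound 4 `COc1cc(-c2nn(-c3cccc(NC(=O)Nc4cc(C(F)(F)F)cc(C(F)(F)F)c4)c3)cc2-c2ccncc2)ccc1Cl` differs from compound 2 by trifluoromethyl in place of hydrogen on an aromatic carbon. Going by the values given here, no measured step bears on this change directly, though compound 1, which carries the same bis(trifluoromethyl)phenyl urea, gives 1090 nM. Compound 4 is therefore expected to show a step of a 1.1-fold lower number from compound 2 to compound 4 (0.06 log units; within the scatter), with no change beyond the scatter. The estimated value of compound 4 is 1100 nM, with a range from 500 nM to 2500 nM.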

Compound 4, concentration for 50% growth inhibition: 1210 nM
Estimate against measurement, compound 4: 1.1-fold (0.04 log units) below; measured number inside the range.
By their numbers in this assay, from the lowest: compounds 1, 4, 2 and 3 (each within the scatter of the next).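

In this assay, trifluoromethyl in place of hydrogen on the aromatic carbon of the urea terminus gives a 1.0-fold lower number from compound 2 to compound 4 (0.01 log units; within the scatter), so this change at this position leaves the number unmoved beyond the scatter. With the bis(trifluoromethyl)phenyl urea held fixed, methyl in place of hydrogen on the oxygen gives a 1.1-fold higher number from compound 1 to compound 4 (0.05 log units; within the scatter), showing that this second position is equally flat. Nothing available explains either result.

On these data alone, whether an amine or a carboxylic acid on this aromatic carbon would move the number beyond the scatter remains open. So does the effect of a longer chain on the oxygen.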